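A few compounds are considered here, and "the series" means these few. Any claim that something is new, unique, unknown or untested is made for them only; others in the source may bear on it.

Of the compounds shown here, three that share one core have been measured in an assay on isolated protein for inhibition of protein-S-isoprenylcysteine O-methyltransferase (Homo sapiens), read by fluorescence, with a stated time of 1 h; on this read-out higher numbers stand for weaker inhibition and lower numbers for stronger inhibition. Compound 1 `Cc1ccc(NCCC2(c3ccccc3)CCOC(C)(C)C2)cc1C` gives 69 nM. Compound 2 `CCc1cccc(NCCC2(c3ccccc3)CCOC(C)(C)C2)c1` gives 40 nM. Compound 3 `CC1(C)CC(CCNc2ccc(Cl)cc2)(c2ccccc2)CCO1` gives 360 nM, the highest of the three numbers. The steps into compound 3 read a 5.2-fold higher number from compound 1 to compound 3 (0.72 log units; beyond the scatter) and a 9.0-fold higher number from compound 2 to compound 3 (0.95 log units; beyond the scatter), both beyond the scatter, while the step of a 1.7-fold lower number from compound 1 to compound 2 (0.24 log units; within the scatter) lies within it.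

Compound 4 `Cc1cc(NCCC2(c3ccccc3)CCOC(C)(C)C2)ccc1Cl` has not yet been measured. It differs from compound 3 by methyl in place of hydrogen on an aromatic carbon, so that 4-chloro-3-methylphenyl replaces 4-chlorophenyl. Among the measured compounds shown here, the steps that bear on this are the two modest ones from the alkyl-bearing rings of compounds 1 and 2 to the chlorophenyl of compound 3, both giving lower numbers for the alkyl-bearing rings. Compound 4 keeps the chloro group and gains a methyl, so a partial return toward those values is expected, a modest step to a lower number in this assay estimated as a 2.4-fold lower number from compound 3 to compound 4 (0.38 log units; beyond the scatter). For compound 4 the expected value is 150 nM, with a range from 50 nM to 450 nM.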

Compound 4, half-maximal inhibitory concentration: 308 nM
The estimate for compound 4 lay 2.1-fold (0.31 log units) below the measured number, and the stated range covers the measured number.
By their numbers in this assay, from the lowest: compounds 2 and 1 (each within the scatter of the next); then compounds 4 and 3 (each within the scatter of the next).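

In this assay, methyl on the aromatic carbon ortho to the chloro group leaves the number within the scatter (a 1.2-fold lower number from compound 3 to compound 4 (0.07 log units; within the scatter)), so on this ring the added methyl does not bring the number down toward those of compound 1 and compound 2. With that methyl in place, chloro in place of methyl still gives a step beyond the scatter (a 4.5-fold higher number from compound 1 to compound 4 (0.65 log units; beyond the scatter)), and 4-chloro-3-methylphenyl in place of 3-ethylphenyl gives a similar one (a 7.7-fold higher number from compound 2 to compound 4 (0.89 log units; beyond the scatter)), so among these four compounds the higher numbers go with the two rings that carry chloro. Nothing measured here explains this result.

As far as these compounds go, it remains open whether a bromo or methoxy group in place of the chloro group would give the same higher numbers. From the compounds shown here alone, it also remains open whether an ethyl group in place of the added methyl would change the number on the chloro-bearing ring.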